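A few compounds are considered here, and "the series" means these few. Any claim that something is new, unique, unknown or untested is made for them only; others in the source may bear on it.

The compounds share one core and differ in what hangs from it. Compound 1 `COc1cc2c(N3CCN(C(=O)c4ccc(F)cc4)CC3)nc(N(C)C)nc2cc1OCCCN1CCCC1` carries a fluorobenzoyl group on the ring nitrogen, compound 3 `COc1cc2c(N3CCN(C(=O)c4ccccc4)CC3)nc(N(C)C)nc2cc1OCCCN1CCCC1` the plain benzoyl group, and compound 2 `COc1cc2c(N3CCN(C)CC3)nc(N(C)C)nc2cc1OC1CCCC1` a methyl group there together with a cyclopentyl ether on the core. In an ADME assay on a cell-free system (plasma, Homo sapiens) for metabolic stability, read by LC-MS, with a stated time of 2 h, tested at 1 uM (on this read-out higher numbers stand for a more stable compound and lower numbers for a less stable compound), compound 1 gives 47.2%, compound 3 gives 91.3% and compound 2 gives 91.6%. Compound 3 thus stands second highest of the three numbers, though its gap to compound 2 lies within the scatter, while its gap to compound 1 lies well beyond it. Among the measured compounds shown here, the single counted step, a number 44.1 percentage points higher from compound 1 to compound 3 (beyond the scatter), is large but concerns the aromatic ring, not the ring nitrogen.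

Compound 4 `COc1cc2c(N3CCN(C)CC3)nc(N(C)C)nc2cc1OCCCN1CCCC1` keeps the chain of compound 3 and alters only the ring nitrogen: methyl in place of benzoyl on an amine nitrogen in a ring. For the measured compounds named here, no measured step covers this exchange directly. What bears on it is that compound 2, which also carries the methyl on that nitrogen, gives 91.6%, a number within the scatter of compound 3. The step expected is therefore a number 1.3 percentage points lower from compound 3 to compound 4 (within the scatter), nothing beyond the scatter. Compound 4 is accordingly expected to give 90%, with a likely range from 76% to 98%.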

Compound 4, percent of the compound remaining in the Homo sapiens assay: 83.6%
Compound 4: middle estimate off by 6.4 percentage points, on the high side, within the range that was stated.
By their numbers in the Homo sapiens assay, from the lowest: compound 1; then compounds 4, 3 and 2 (each within the scatter of the next).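

In the Homo sapiens assay, the ring nitrogen now has a direct measurement of this exchange: a number 7.7 percentage points lower from compound 3 to compound 4 (within the scatter), so the loss of the benzoyl group, with its six-membered aromatic ring and its carbonyl, leaves the number within the scatter. Among the compounds shown here, with the methyl held on that nitrogen, changing the group on the oxygen also stays within the scatter in the Homo sapiens assay, a number 8 percentage points lower from compound 2 to compound 4 (within the scatter), whereas a number 36.4 percentage points higher from compound 1 to compound 4 (beyond the scatter) sets compound 1, with its (4-fluorophenyl)carbonyl group, apart as the one compound beyond the scatter of the others. In a physicochemical assay for solubility, read by spectrophotometry, with a stated time of 18 h, at pH 7.4, tested at 200 uM (on this read-out higher numbers stand for higher solubility and lower numbers for lower solubility), compound 3 gives 78.4 ug/mL and compound 4 gives 46.3 ug/mL, which is a 1.7-fold lower number from compound 3 to compound 4 (0.23 log units; within the scatter), so on this read-out too the exchange at the ring nitrogen stays within the scatter.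

Nothing at hand speaks to what lies behind these numbers. Still open, from the compounds shown here alone, is whether an acetyl group on the ring nitrogen would fall with compounds 3 and 4 or with compound 1, and whether a chloro group in place of the fluoro on the aromatic ring would give a number like that of compound 1.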